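Swapping the Aryl Arm: Cytotoxicity of Compound 4

A few compounds are considered here, and "the series" means these few. Any claim that something is new, unique, unknown or untested is made for them only; others in the source may bear on it.

Measured compounds:
Compound 1, `COc1cc(/C=C2\CCC/C(=C\c3ccccc3Br)C2=O)cc(OC)c1OC`, gives 12400 nM in an ADME assay on NHDF cells (Homo sapiens) for cytotoxicity; on this read-out higher numbers stand for weaker inhibition and lower numbers for stronger inhibition.
Compound 2, `COc1cc(/C=C2\CCC/C(=C\c3ccccc3F)C2=O)cc(OC)c1OC`, gives 4000 nM.
Compound 3, `COc1cc(/C=C2\CCC/C(=C\c3ccc(O)c(Cl)c3)C2=O)cc(OC)c1OC`, gives 6900 nM.

Compound 3 holds the second highest of the three numbers in this assay, and neither of its neighbours is separated from it by more than the scatter: a 1.8-fold lower number from compound 1 to compound 3 (0.25 log units; within the scatter), and a 1.7-fold higher number from compound 2 to compound 3 (0.24 log units; within the scatter). Only the halogen swap between the two remaining compounds reaches beyond the scatter, a 3.1-fold lower number from compound 1 to compound 2 (0.49 log units; beyond the scatter), and even that is modest.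

Compound 4, `COc1ccccc1/C=C1\CCC/C(=C\c2cc(OC)c(OC)c(OC)c2)C1=O`, differs from compound 3 in a single place: 2-methoxyphenyl in place of 3-chloro-4-hydroxyphenyl on a double-bonded chain carbon bound to a double-bonded ring carbon.

For the measured compounds named here, the steps that bear on this change are the two that already exchange the whole aryl group at this same place, from compound 1 and from compound 2 to compound 3, and both stay within the scatter. The halogen step between compound 1 and compound 2 shows what size a change at this arm can reach, but nothing larger. The expectation for compound 4 is therefore no step beyond the scatter, a 1.0-fold higher number from compound 3 to compound 4 (0.01 log units; within the scatter), in this assay. Compound 4 is estimated at 7000 nM, with a range from 3000 nM to 16000 nM.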

Compound 4, half-maximal inhibitory concentration: 7900 nM
Compound 4: middle estimate off by 1.1-fold (0.05 log units), on the low side, within the range that was stated.
By their numbers in this assay, from the lowest: compounds 2, 3, 4 and 1 (each within the scatter of the next, the first and the last beyond it).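

Read in this assay, the aryl arm takes a further whole exchange without a step beyond the scatter: 2-methoxyphenyl replaces 3-chloro-4-hydroxyphenyl, which removes the chlorine and the hydrogen-bond donor while the count of heavy atoms stays the same (a 1.1-fold higher number from compound 3 to compound 4 (0.06 log units; within the scatter)). Methoxy in place of a halogen on the aromatic carbon also stays within the scatter for both halogens, fluoro (a 2.0-fold higher number from compound 2 to compound 4 (0.30 log units; within the scatter)) and bromo (a 1.6-fold lower number from compound 1 to compound 4 (0.20 log units; within the scatter)), so compound 4 cannot be told apart from either halogen compound, although compound 1 and compound 2 stand beyond the scatter of each other. Giving up the chlorine and the donor together therefore leaves no readable mark on this cytotoxicity read-out in this pair.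

As far as these compounds go, whether a group of another kind on this arm, such as an amine, a carboxylic acid or a longer chain in place of the methoxy, would give a step beyond the scatter stays open, as does any change to the other arm, which is the same in all four compounds. Nothing shown here speaks to the cause of any of these steps, the halogen swap included.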